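Swapping the Aryl Group on the Amine Nitrogen

The source may hold more compounds than are shown below. What is called first, only, known or untested is meant among the compounds shown, and "the series" means these compounds.

Three compounds share one core and differ only in the group carried on the amine nitrogen. Compound 1 `COc1ccc(NCC(=O)Oc2ccc3c(C)cc(=O)oc3c2)cc1` bears a 4-methoxyphenyl there, and in a functional assay on the whole organism (strain Wistar albino) for inhibition, with Rattus norvegicus as the target, read by paw edema, with stated times of 30 min and 1 h, at a dose of 20 mg/kg by the oral route (a higher number here means more inhibition at the dose given (going by the name of the read-out), a lower number less inhibition), compound 1 gives 30.3%. Compound 3 `Cc1cc(=O)oc2cc(OC(=O)CNc3nc4ccccc4s3)ccc12` gives 30.3% in this assay, level with compound 1 at the digits shown, so the two stand together at the top of the three numbers. Compound 2 `COc1ccccc1NCC(=O)Oc1ccc2c(C)cc(=O)oc2c1` gives 10.7% in this assay; with 2-methoxyphenyl in place of 4-methoxyphenyl on an amine nitrogen, the step is a number 19.6 percentage points lower from compound 1 to compound 2 (beyond the scatter), and compound 2 is the furthest of the three from compound 1.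

Compound 4 `Cc1cc(=O)oc2cc(OC(=O)CNc3ccccc3Cl)ccc12` has not been measured. It differs from compound 1 in one place: 2-chlorophenyl in place of 4-methoxyphenyl on an amine nitrogen. Among the measured compounds shown here, the one measured step that touches the same position is the one from compound 1 to compound 2, a modest fall beyond the scatter when the 4-methoxyphenyl was exchanged for another aryl group. On that single precedent, a fall of similar size is expected in this assay, giving a number 12.3 percentage points lower from compound 1 to compound 4 (beyond the scatter). Compound 4 is therefore estimated at 18% in this assay, within a range from 5% to 32%.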

Compound 4, a percentage reported as inhibition, in the whole organism at one dose (the size of the read-out at that dose, not a potency): 21.4%
For compound 4 the middle estimate is 3.4 percentage points below the measured one, and the stated range covers the measured number.
By their numbers in this assay, from the lowest: compound 2; then compounds 4, 1 and 3 (each within the scatter of the next).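

Among the compounds shown here, with the 2-chlorophenyl on the amine nitrogen, this assay gives a number 8.9 percentage points lower from compound 1 to compound 4 (within the scatter), so this exchange of the 4-methoxyphenyl, unlike the one that gave compound 2, cannot be told apart from no change. The loss seen with compound 2 therefore does not extend to every replacement at this position, and it is not shared by both compounds that carry a 2-substituted phenyl group. With the ring otherwise the same, the change of substituent alone gives a number 10.7 percentage points higher from compound 2 to compound 4 (beyond the scatter), which shows that methoxy and chloro at this place can be told apart in this read-out, although nothing given here bears on why the numbers differ.

Still open, as far as these compounds go, is how an unsubstituted phenyl on the amine nitrogen would read, and whether a bromo or a methyl in place of the chloro would stand closer to compound 4 or to compound 2. A longer chain between the amine nitrogen and the ester is also open, and since each number is the size of the effect at a single dose, the potency of these compounds remains unknown.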